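Compound 3: anilino to 3,4-difluorophenyl on the carbonyl

The source may report more compounds than this note shows. Statements on the series, on what has been measured and on what is new or still open speak of the compounds shown alone.

Compound 1 `CC(C)[C@@H](NC(=O)NCc1ccccc1)C(=O)N1CCC(c2ccc(Cl)cc2)CC1` and compound 2 `CC(C)[C@@H](NC(=O)Nc1ccccc1)C(=O)N1CCC(c2ccc(Cl)cc2)CC1` share a core and differ only in the group on the amide-type nitrogen. In an assay on THP-1 cells for displacement of a labelled ligand from C-C chemokine receptor type 1 (Homo sapiens) (on this read-out higher numbers stand for weaker inhibition and lower numbers for stronger inhibition), compound 1 gives 180 nM and compound 2 gives 616 nM; the step of a 3.4-fold higher number from compound 1 to compound 2 (0.53 log units; beyond the scatter) lies beyond the scatter, so compound 2 stands highest of the two numbers, with compound 1 as its nearest neighbour. Compound 3 `CC(C)[C@@H](NC(=O)c1ccc(F)c(F)c1)C(=O)N1CCC(c2ccc(Cl)cc2)CC1` arises from compound 2 by 3,4-difluorophenyl in place of anilino on a carbonyl carbon. For the measured compounds named here, no measured pair covers this change; the only step in hand, a 3.4-fold higher number from compound 1 to compound 2 (0.53 log units; beyond the scatter), swaps the substituent on the amide-type nitrogen rather than removing that nitrogen, and it shows only a modest shift in that region. Going by the values given here, with no direct precedent, the expected step of a 1.4-fold lower number from compound 2 to compound 3 (0.14 log units; within the scatter) for compound 3 is not beyond the scatter in either direction. Compound 3 is therefore estimated at 450 nM, within 150 nM to 1400 nM in this assay.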

Compound 3, half-maximal inhibitory concentration: 14 nM
Compound 3: middle estimate off by 32-fold (1.51 log units), on the high side; the whole stated range lies above it.
By their numbers in this assay, from the lowest: compound 3; then compound 1; then compound 2.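

In this assay, 3,4-difluorophenyl on the carbonyl carbon outperforms both nitrogen-linked groups: in place of anilino it gives a 44-fold lower number from compound 2 to compound 3 (1.64 log units; beyond the scatter), and in place of benzylamino it gives a 13-fold lower number from compound 1 to compound 3 (1.11 log units; beyond the scatter). Both steps are large, whereas changing only the group on the amide-type nitrogen gave the modest 3.4-fold higher number from compound 1 to compound 2 (0.53 log units; beyond the scatter). An amide-type nitrogen at this place is therefore not needed for strong inhibition, and replacing the whole group on the carbonyl carbon moves the number much further than swapping benzyl for phenyl on that nitrogen.

From the compounds shown here alone, the change removes the nitrogen and adds two fluorines at once, so the contribution of each stays open until a plain phenyl or a monofluorophenyl on the carbonyl is compared. No available data indicate why the number falls.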